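Bromophenyl in place of fluorophenyl on the triazole ring

The source may hold more compounds than are shown below. What is called first, only, known or untested is meant among the compounds shown, and "the series" means these compounds.

Compound 1 `COc1cc2c(Oc3ccc(NC(=O)c4cn(-c5ccc(Br)cc5)nn4)cc3F)ccnc2cc1OCCCN1CCCC1`: in a functional assay on HT-29 cells (Homo sapiens) for cytotoxicity, read by MTT assay, with a stated time of 72 h (on this read-out higher numbers stand for weaker inhibition and lower numbers for stronger inhibition), compound 1 gives 190 nM.
Compound 2 `COc1cc2c(Oc3ccc(NC(=O)c4cn(-c5ccccc5C)nn4)cc3F)ccnc2cc1OCCCN1CCCCC1`: in this assay compound 2 gives 1340 nM.
Compound 3 `COc1cc2c(Oc3ccc(NC(=O)c4cn(-c5ccccc5F)nn4)cc3F)ccnc2cc1OCCCN1CCCCC1`: in this assay compound 3 gives 290 nM.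

Compound 3 stands second highest of these three numbers, within the scatter of compound 1 and beyond the scatter from compound 2. Compound 4 `COc1cc2c(Oc3ccc(NC(=O)c4cn(-c5ccc(Br)cc5)nn4)cc3F)ccnc2cc1OCCCN1CCCCC1` has not been measured. The change from compound 3 to compound 4 is 4-bromophenyl in place of 2-fluorophenyl on an aromatic nitrogen. For the measured compounds named here, the one measured single-point step, a 4.6-fold lower number from compound 2 to compound 3 (0.66 log units; beyond the scatter), concerns a different pair of groups on that ring and bears only loosely on this change. Compound 4 shares its 4-bromophenyl with compound 1, which in this assay gives 190 nM, a number within the scatter of compound 3. For compound 4 the expected step is therefore small, a 1.3-fold lower number from compound 3 to compound 4 (0.12 log units; within the scatter). Compound 4 is estimated at 220 nM, with a range from 90 nM to 600 nM.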

Compound 4, half-maximal inhibitory concentration: 260 nM
For compound 4 the middle estimate is 1.2-fold (0.07 log units) below the measured one; the range from low to high includes it.
By their numbers in this assay, from the lowest: compounds 1, 4 and 3 (each within the scatter of the next); then compound 2.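

In this assay, 4-bromophenyl and 2-fluorophenyl on the triazole nitrogen cannot be told apart (a 1.1-fold lower number from compound 3 to compound 4 (0.05 log units; within the scatter)), while 4-bromophenyl stands clearly apart from 2-methylphenyl (a 5.2-fold lower number from compound 2 to compound 4 (0.71 log units; beyond the scatter)). For the compounds shown here, compound 4 also allows a first direct comparison at the far end of the side chain, where piperidin-1-yl and pyrrolidin-1-yl cannot be told apart either (a 1.4-fold higher number from compound 1 to compound 4 (0.14 log units; within the scatter)).

No measured evidence explains these results. The halogen and its place on the phenyl ring change together here. 4-fluorophenyl or 2-bromophenyl would be needed to separate the two changes.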